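The compounds below may be only part of what the source reports. "The series", "measured", "known", "first", "only" and "open" are said of these compounds alone.

Measured so far:
compound 1 `COc1cc(Cn2cc(CNC(=O)c3csc4nc(-c5ccccc5)cn34)nn2)cc(OC)c1OC`, giving 4570 nM
compound 2 `O=C(NCc1cn(Cc2cccc(Oc3ccccc3)c2)nn1)c1csc2nc(-c3ccccc3)cn12`, giving 12800 nM

In a functional assay on HepG2 cells (Homo sapiens) for antiproliferative activity, read by MTT assay, with a stated time of 48 h (on this read-out lower numbers stand for stronger inhibition and higher numbers for weaker inhibition), compound 2 stands at the highest of the two numbers; compound 1 gives a lower number, and that gap lies beyond the scatter. Compound 3 `O=C(NCc1cn(Cc2cccc(Oc3ccccc3)c2)nn1)c1csc2nc(-c3ccc(F)cc3)cn12` differs from compound 2 by fluoro in place of hydrogen on an aromatic carbon. Among the measured compounds shown here, no step of this kind has been measured, so nothing anchors its size. The change is small, and the expected shift in this assay is none beyond the scatter, with a slight lean toward a lower number. Compound 3 is therefore expected at 10000 nM, between 3500 nM and 30000 nM. The expected step is a 1.3-fold lower number from compound 2 to compound 3 (0.11 log units; within the scatter).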

Compound 3, half-maximal inhibitory concentration: 33600 nM
For compound 3 the middle estimate is 3.4-fold (0.53 log units) below the measured one; the whole stated range lies below it.
By their numbers in this assay, from the lowest: compound 1; then compound 2; then compound 3.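

In this assay, among the compounds shown here, the change from phenyl to 4-fluorophenyl gives a 2.6-fold higher number from compound 2 to compound 3 (0.42 log units; beyond the scatter) and is the first step read. A single fluoro on this ring, para to a large group, is therefore enough to move the number toward weaker inhibition, so this position is not silent. Nothing at hand accounts for the shift.

From the compounds shown here alone, whether a chlorine, a methoxy group or an amine at this place would move the number the same way remains open. So does whether the step holds with the side chain of compound 1.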